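A few compounds are considered here, and "the series" means these few. Any claim that something is new, unique, unknown or untested is made for them only; others in the source may bear on it.

Three compounds have been measured in an assay on nucleic acid for inhibition of Nucleic Acid, read by fluorescence, tested at 100 uM; a lower number here means less inhibition, a higher number more inhibition at the concentration tested (going by the name of the read-out):

compound 1 `CN(Cc1cn(C2CCCCC2OC(=O)c2ccccc2)nn1)CC1CCCCC1`, 32%
compound 2 `O=C(OC1CCCCC1n1cc(CN2CCC(c3ccccc3)CC2)nn1)c1ccccc1`, 16%
compound 3 `CC(C)CCN(C)Cc1cn(CC(O)COC(=O)c2ccccc2)nn1`, 0%

Compound 1 stands highest of the three numbers. Compound 2 comes nearest, lower by a margin beyond the usual scatter, and compound 3 lies furthest, lower again by a margin beyond the scatter.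

Compound 4 `CN(Cc1cn(C2CCCCC2OC(=O)COc2ccccc2)nn1)CC1CCCCC1` differs from compound 1 in one place: phenoxymethyl in place of phenyl on a carbonyl carbon. For the measured compounds named here, no pair of measured compounds shows this kind of change, so nothing measured speaks to its size. The expectation is a modest lowering in this assay, within or barely beyond the scatter, because compound 1 starts from 32%. Compound 4 is expected at 22%, within 5% to 40%. The expected step is a number 10 percentage points lower from compound 1 to compound 4 (within the scatter).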

Compound 4, a percentage reported as inhibition, at one concentration (the size of the read-out at that concentration, not a potency): 37%
For compound 4 the middle estimate is 15 percentage points below the measured one; measured number inside the range.
By their numbers in this assay, from the lowest: compound 3; then compound 2; then compounds 1 and 4 (each within the scatter of the next).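

In this assay, for the compounds shown here, phenoxymethyl in place of phenyl on a carbonyl carbon gives a number 5 percentage points higher from compound 1 to compound 4 (within the scatter) and so is the first change at this position that can be read. The larger group, with its one hydrogen-bond acceptor, leaves the number within the scatter of compound 1, so this single change shows no effect. Nothing available accounts for this result.

Going by these compounds, whether an amine or a longer chain in place of phenyl on a carbonyl carbon would move the number beyond the scatter stays open. So does whether phenoxymethyl would behave alike on compound 2.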